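This account rests on a few compounds, and the source may have more. Where it says the series, first, only, none or still open, it means among the compounds named here.

Of the compounds shown here, three sharing one core have been tested in a functional assay on the whole organism (strain Wistar) for inhibition, with Rattus norvegicus as the target, read by paw edema, with stated times of 60 min and 3 h, at a dose of 100 mg/kg by the oral route; a higher number here means more inhibition at the dose given (going by the name of the read-out), a lower number less inhibition. Compound 1 `CNC(=O)CC1CCc2cc(OC)c(OC)cc21` gives 29%. Compound 2 `CCN(CC)C(=O)CC1CCc2cc(OC)c(OC)cc21` gives 37.7%. Compound 3 `CCCNC(=O)CC1CCc2cc(OC)c(OC)cc21` gives 29%. Compound 2 holds the highest of the three numbers, yet the gaps to its neighbours are small: the step from compound 1 to compound 2 is a number 8.7 percentage points higher from compound 1 to compound 2 (within the scatter), and from compound 2 to compound 3 it is a number 8.7 percentage points lower from compound 2 to compound 3 (within the scatter), both within the scatter of repeated tests. Between compound 1 and compound 3 the step is no change at the digits printed from compound 1 to compound 3 (within the scatter). In short, changing the amine part of the amide has so far left the read-out essentially unchanged.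

Compound 4 `COc1cc2c(cc1OC)C(CC(=O)N1CCCC1)CC2` is the next step from compound 2, with the difference (pyrrolidin-1-yl in place of diethylamino on a carbonyl carbon). Among the measured compounds shown here, the two groups are of the same size and carry no donor or acceptor, so the only precedent is the set of amine variations above, none of which moved the number beyond the scatter. The step from compound 2 to compound 4 is therefore expected to be a number 2.7 percentage points lower from compound 2 to compound 4 (within the scatter), with no clear direction. Compound 4 is estimated to give 35%, within a range from 22% to 48%.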

Compound 4, a percentage reported as inhibition, in the whole organism at one dose (the size of the read-out at that dose, not a potency): 26.1%
Estimate against measurement, compound 4: 8.9 percentage points above; the measured number falls inside the stated range.
By their numbers in this assay, from the lowest: compounds 4, 1, 3 and 2 (each within the scatter of the next, the first and the last beyond it).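

In this assay, among the compounds shown here, tying the two ethyl groups of diethylamino into the pyrrolidin-1-yl ring gives a number 11.6 percentage points lower from compound 2 to compound 4 (beyond the scatter) and is the first step to pass the scatter, though only modestly. The two groups have the same heavy-atom count and neither has a hydrogen-bond donor or acceptor, so on the carbonyl carbon, a ring in place of an open chain is enough to separate two compounds that these counts do not distinguish. For the compounds shown here, the other two comparisons remain flat, with a number 2.9 percentage points lower from compound 3 to compound 4 (within the scatter) and a number 2.9 percentage points lower from compound 1 to compound 4 (within the scatter) both staying within the scatter, and compound 2 also stays within the scatter of compounds 1 and 3, so only the pair of compound 2 and compound 4 stands apart. No measurement shown here bears on why the ring and the open chain differ.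

From the compounds shown here alone, it remains open whether a larger ring such as piperidin-1-yl or morpholin-4-yl on the same carbonyl carbon would read like pyrrolidin-1-yl or like diethylamino. A longer pair of chains, such as dipropylamino, would test whether the open tertiary amide form holds up, and all these numbers come from a single dose.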